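Trifluoromethoxy in place of methylsulfanyl on a receptor ligand

This account rests on a few compounds, and the source may have more. Where it says the series, first, only, none or still open, it means among the compounds named here.

Compound 1 `COC(=O)/C=C/c1cccc(N(Cc2ccc(/C=C/c3c(C)cc(C)cc3C)cc2)C(=O)C(C)C)c1` gives 149 nM
Compound 2 `COC(=O)/C=C/c1cccc(N(Cc2ccc(-c3ccc(SC)cc3)cc2)C(=O)C(C)C)c1` gives 51 nM
Compound 3 `CCOc1cccc(-c2ccc(CN(C(=O)C3CCCCC3)c3cccc(/C=C/C(=O)OC)c3)cc2)c1` gives 147 nM

These three compounds were tested in an assay on isolated protein with Bile acid receptor (Homo sapiens) as the target; on this read-out lower numbers stand for an effect already at smaller amounts and higher numbers for an effect only at larger amounts of compound. Compound 2 has the lowest number of the three; compound 3 and compound 1 each give a higher number, and both gaps lie beyond the scatter. Compound 4 `COC(=O)/C=C/c1cccc(N(Cc2ccc(-c3ccc(OC(F)(F)F)cc3)cc2)C(=O)C(C)C)c1` has not been measured. It differs from compound 2 by trifluoromethoxy in place of methylsulfanyl on an aromatic carbon. Among the compounds with values here, no measured step makes this exact change; the only step at that aromatic carbon is a 2.9-fold lower number from compound 1 to compound 2 (0.47 log units; beyond the scatter), which shows that a change there can shift the number modestly. Since nothing here speaks for either direction, the expected step is a 1.6-fold higher number from compound 2 to compound 4 (0.20 log units; within the scatter), a small one. The estimate for compound 4 is 80 nM, within a range from 25 nM to 250 nM.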

Compound 4, half-maximal effective concentration: 219 nM
Beside the measured number, compound 4's estimate is 2.7-fold (0.44 log units) below it; the measured number falls inside the stated range.
By their numbers in this assay, from the lowest: compound 2; then compounds 3, 1 and 4 (each within the scatter of the next).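

In this assay, trifluoromethoxy in place of methylsulfanyl gives a 4.3-fold higher number from compound 2 to compound 4 (0.63 log units; beyond the scatter) and so shows that these two groups are not interchangeable at this aromatic carbon. The other comparison, a 1.5-fold higher number from compound 1 to compound 4 (0.17 log units; within the scatter), shows that the lower number of compound 2 does not come with every substituted phenyl at this position, only with 4-(methylsulfanyl)phenyl so far. Nothing measured here explains the difference between the two groups. As far as these compounds go, it remains open how an amine or a carboxylic acid would fare in place of methylsulfanyl at this carbon.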